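The source may report more compounds than this note shows. Statements on the series, on what has been measured and on what is new or still open speak of the compounds shown alone.

Measured in a physicochemical assay for solubility, in phosphate buffer, at pH 6.5; a higher number here means a more soluble compound, a lower number a less soluble compound:

Compound 1 `C=C[C@@H]1C[C@]1(NC(=O)[C@@H]1C[C@@H](Oc2nccc3cc(OC)ccc23)CN1C(=O)[C@@H](NC(=O)N[C@@H](C)COC)C(C)(C)C)C(=O)NS(=O)(=O)C1CC1` gives 1070 ug/mL
Compound 2 `C=C[C@@H]1C[C@]1(NC(=O)[C@@H]1C[C@@H](Oc2nccc3cc(OC)ccc23)CN1C(=O)[C@@H](NC(=O)N[C@H](COC)c1ccccc1)C(C)(C)C)C(=O)NS(=O)(=O)C1CC1` gives 259 ug/mL
Compound 3 `C=C[C@@H]1C[C@]1(NC(=O)[C@@H]1C[C@@H](Oc2nccc3cc(OC)ccc23)CN1C(=O)[C@@H](NC(=O)N[C@H](C(=O)OC(C)(C)C)C(C)(C)C)C(C)(C)C)C(=O)NS(=O)(=O)C1CC1` gives 1 ug/mL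

Of these three, compound 3 stands lowest, at 1 ug/mL. The three differ only in the group on an amide-type nitrogen of the shared core. Swapping methyl for phenyl on that group gave a modest drop, a 4.1-fold lower number from compound 1 to compound 2 (0.62 log units; beyond the scatter). The change to the group carried by compound 3 gave much bigger drops: a 1100-fold lower number from compound 1 to compound 3 (3.03 log units; beyond the scatter), and a 260-fold lower number from compound 2 to compound 3 (2.41 log units; beyond the scatter).

Compound 4 `C=C[C@@H]1C[C@]1(NC(=O)[C@@H]1C[C@@H](Oc2nccc3cc(OC)ccc23)CN1C(=O)[C@@H](NC(=O)N[C@H](C(N)=O)C(C)(C)C)C(C)(C)C)C(=O)NS(=O)(=O)C1CC1` has not yet been measured. It differs from compound 3 at one place: amino in place of tert-butoxy on a carbonyl carbon. Put simply, this is amino in place of tert-butoxy on a carbonyl carbon, which turns tert-butoxycarbonyl into carbamoyl. Among the measured compounds shown here, no measured step makes this exact swap, so the forecast is uncertain. Still, a 260-fold lower number from compound 2 to compound 3 (2.41 log units; beyond the scatter) shows that this part of the molecule can shift the number a long way, and compound 3 sits at the very bottom of the series. A large rise is therefore expected, probably without a full return to the level of compound 1 at 1070 ug/mL. The estimated step is a 100-fold higher number from compound 3 to compound 4 (2.00 log units; beyond the scatter). For compound 4 the expected value is 100 ug/mL, with an estimated range from 15 ug/mL to 600 ug/mL.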

Compound 4, solubility: 557 ug/mL
Estimate against measurement, compound 4: 5.6-fold (0.75 log units) below; measured number inside the range.
By their numbers in this assay, from the lowest: compound 3; then compound 2; then compounds 4 and 1 (each within the scatter of the next).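

On the carbonyl carbon, amino in place of tert-butoxy changes the number by a large margin in this assay (a 560-fold higher number from compound 3 to compound 4 (2.75 log units; beyond the scatter)), so the very low reading of compound 3 depends on the tert-butoxy group and not on the 2,2-dimethylpropyl part, which both compounds share. With amino in place, that same 2,2-dimethylpropyl part no longer marks the series' low end: the step against the phenyl-bearing group is modest (a 2.2-fold higher number from compound 2 to compound 4 (0.33 log units; beyond the scatter)), and the step against the 1-(methoxymethyl)ethyl group does not exceed the usual scatter (a 1.9-fold lower number from compound 1 to compound 4 (0.28 log units; within the scatter)). No measurement shown here explains why this swap has so large an effect.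

The compounds shown hold only two groups on this carbonyl carbon, so it remains open where a carboxylic acid, a methyl ester or a dimethylamide would fall between these readings. Also open, going by these compounds, is how amino on the carbonyl would read with a smaller chain, such as an ethyl chain, in place of the 2,2-dimethylpropyl part.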